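Replacing an alkynyl alcohol with an octyl chain

A few compounds are considered here, and "the series" means these few. Any claim that something is new, unique, unknown or untested is made for them only; others in the source may bear on it.

Measured compounds:
compound 1 `CC(=O)Nc1nc(-c2cccc(NS(=O)(=O)c3ccc(C#CCO)cc3)c2)cs1` — 81.3%
compound 2 `CCCCCCC#Cc1cccc(S(=O)(=O)Nc2cccc(-c3csc(NC(C)=O)n3)c2)c1` — 56.9%

Of the compounds shown here, two sharing the same core have been measured in a functional assay on A-375 cells (Homo sapiens) for antiproliferative activity, read by trypan blue exclusion, with a stated time of 48 h, tested at 1 uM; on this read-out higher numbers stand for a weaker effect at the one concentration tested and lower numbers for a stronger effect. Compound 1 gives 81.3%, the highest of the two numbers; compound 2 gives 56.9%, a number lower than that of compound 1 by more than the usual scatter, so compound 2 shows the stronger effect of the two at the single concentration tested.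

Compound 3 `CCCCCCCCc1ccc(S(=O)(=O)Nc2cccc(-c3csc(NC(C)=O)n3)c2)cc1` has not yet been measured. It differs from compound 1 by the change octyl in place of 3-hydroxyprop-1-yn-1-yl on an aromatic carbon: the 3-hydroxyprop-1-yn-1-yl group leaves and an octyl group enters on an aromatic carbon of a six-membered aromatic ring of carbon only, para to a large group. Going by the values given here, no single-change step between measured compounds exists that could be used as a guide, so the expectation rests only on the two values shown. Since compound 2, which carries a long carbon chain on the same ring, gives 56.9%, a step downward beyond the scatter is expected for compound 3 in this assay, estimated as a number 21.3 percentage points lower from compound 1 to compound 3 (beyond the scatter). Compound 3 is therefore expected to give about 60%, within a range from 40% to 80%.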

Compound 3, a percentage reported as activity, at one concentration (the size of the read-out at that concentration, not a potency): 34.8%
Beside the measured number, compound 3's estimate is 25.2 percentage points above it; measured number outside the range, below it.
By their numbers in this assay, from the lowest: compound 3; then compound 2; then compound 1.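

Going by these compounds alone, at the aromatic carbon para to a large group, octyl in place of 3-hydroxyprop-1-yn-1-yl gives the first single-change step in this assay, with a number 46.5 percentage points lower from compound 1 to compound 3 (beyond the scatter), so the group at this position clearly affects the read-out at the one concentration tested. Compound 1 and compound 2 differ in more than one place. That earlier pair could not tie a change in the number to this position alone. This single change nevertheless removes a triple bond and a hydroxyl group and brings in a longer all-carbon chain, and the data do not separate these parts, while nothing measured here bears on why the number moves. The compounds shown leave open whether butyl, dodecyl, or an octyl chain ending in a carboxylic acid or an amine would give a stronger or weaker effect at this carbon. They also leave open what 3-hydroxypropyl or prop-1-yn-1-yl would give, which would show whether the hydroxyl group or the triple bond counts for more in this step.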